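A Second Methyl Position on the Shared Core

The source may report more compounds than this note shows. Statements on the series, on what has been measured and on what is new or still open speak of the compounds shown alone.

compound 1 `Cc1ccccc1Cc1ccc(N2CCC[C@H]2CC(=O)O)cc1`: 150 nM
compound 2 `Cc1ccccc1Cc1ccc(N2C[C@@H](C)C[C@H]2CC(=O)O)cc1`: 140 nM

In a functional assay on cells for agonist activity at Free fatty acid receptor 1 (Homo sapiens), read by FLIPR and calcium flux, with a stated time of 100 s (on this read-out lower numbers stand for an effect already at smaller amounts and higher numbers for an effect only at larger amounts of compound), compound 1 gives 150 nM and compound 2 gives 140 nM; the two sit together, since a 1.1-fold lower number from compound 1 to compound 2 (0.03 log units; within the scatter). Compound 3 `Cc1ccccc1Cc1ccc(N2[C@H](CC(=O)O)CC[C@@H]2C)cc1` differs from compound 1 by methyl in place of hydrogen on a saturated ring carbon. For the measured compounds named here, the one step that bears on this, a methyl on another saturated ring carbon from compound 1 to compound 2, stayed within the scatter, so no step beyond the scatter is expected here. Compound 3 is therefore estimated at 160 nM in this assay, with a range of 55 nM to 480 nM, an expected 1.1-fold higher number from compound 1 to compound 3 (0.03 log units; within the scatter).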

Compound 3, half-maximal effective concentration: 6200 nM
For compound 3 the middle estimate is 39-fold (1.59 log units) below the measured one; the whole stated range lies below it.
By their numbers in this assay, from the lowest: compounds 2 and 1 (each within the scatter of the next); then compound 3.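

Placing a methyl in place of hydrogen on the saturated ring carbon next to the ring nitrogen gives a 41-fold higher number from compound 1 to compound 3 (1.62 log units; beyond the scatter) in this assay, while the methyl on another saturated ring carbon gave a 1.1-fold lower number from compound 1 to compound 2 (0.03 log units; within the scatter). The same small change on the shared core therefore has very different results at these two ring carbons, and this position is sensitive to it. Nothing measured here explains that difference. As far as these compounds go, whether an ethyl group or a fluorine atom at this ring carbon would give a similar rise remains open.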